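The source may hold more compounds than are shown below. What is called first, only, known or untested is meant among the compounds shown, and "the series" means these compounds.

Measured so far: compound 1 `COc1ccc(C(=O)/N=C2\NC3(CCCCO3)CCS2)cc1` and compound 2 `O=C(/N=C1\NC2(CCCCO2)CCS1)c1ccc([N+](=O)[O-])cc1`. In a functional assay on the whole organism (strain CF-1) with Mus musculus as the target, in the writhing test, with a stated time of 15 min (a lower number here means that less compound is needed, a higher number that more compound is needed for the effect), compound 1 gives 62 mg/kg; in this assay compound 2 gives 28 mg/kg.

Compound 2 holds the lowest of the two numbers in this assay, with compound 1 as its nearest neighbour. Going by the values given here, the single measured step, a 2.2-fold lower number from compound 1 to compound 2 (0.35 log units; beyond the scatter), concerns a different exchange and only frames the range seen so far. Compound 3 `N#Cc1ccc(C(=O)/N=C2\NC3(CCCCO3)CCS2)cc1` differs from compound 2 in one place: cyano in place of nitro on an aromatic carbon. Among the compounds with values here, no measured step covers this exchange, so no direction can be drawn from the data; a step of about a 1.3-fold higher number from compound 2 to compound 3 (0.10 log units; within the scatter) is expected, within the scatter. For compound 3 in this assay the estimate is 35 mg/kg, with a range of 17 mg/kg to 70 mg/kg.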

Compound 3, dose for half-maximal effect: 60 mg/kg
For compound 3 the middle estimate is 1.7-fold (0.23 log units) below the measured one; the measured number falls inside the stated range.
By their numbers in this assay, from the lowest: compound 2; then compounds 3 and 1 (each within the scatter of the next).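

In this assay, at the aromatic carbon para to a large group, cyano in place of nitro gives a 2.1-fold higher number from compound 2 to compound 3 (0.33 log units; beyond the scatter), so the nitro gain seen against methoxy is not shared by cyano. Cyano in place of methoxy gives a 1.0-fold lower number from compound 1 to compound 3 (0.01 log units; within the scatter), which leaves methoxy and cyano level and nitro alone at the low end of the three. No measurement in hand accounts for this. Open, as far as these compounds go, is how an amine, a carboxylic acid or a chlorine atom at this carbon would compare, and whether nitro keeps its edge elsewhere on the ring.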